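The source may hold more compounds than are shown below. What is called first, only, known or untested is meant among the compounds shown, and "the series" means these compounds.

Compound 1 `C=C[C@@](C)(/C=C/c1ccc(Nc2ccc(OC)c(F)c2)cc1)CCC=C(C)C` and compound 2 `C=C[C@@](C)(/C=C/c1ccc(Nc2ccc(F)cc2)cc1)CCC=C(C)C` share one core and differ only in the group carried on the nitrogen on the aromatic ring. In a functional assay on NALM-6 cells (Homo sapiens) for cytotoxicity, with a stated time of 72 h (a higher number here means that more compound is needed for the effect, a lower number that less compound is needed), compound 1 gives only a limit of the assay, > 43400 nM. In this assay compound 2 likewise gives only a limit, > 43400 nM. The step from compound 1 to compound 2, a step that the two limits leave unreadable from compound 1 to compound 2, cannot be read because both values sit at the same limit (the limit of > 43400 nM in this assay, at which 2 of the 2 values shown sit). Compound 3 `C=C[C@@](C)(/C=C/c1ccc(Nc2ccc(Cl)c(F)c2)cc1)CCC=C(C)C` is not yet measured and differs from compound 2 by 4-chloro-3-fluorophenyl in place of 4-fluorophenyl on a nitrogen on an aromatic ring. Going by the values given here, with both measured values at the limit (the limit of > 43400 nM in this assay, at which 2 of the 2 values shown sit), no measured step bears on this change, so the working expectation is no step beyond the scatter, and a limit again seems the likeliest outcome. Compound 3 is expected at 60000 nM, within 15000 nM to 250000 nM. The expected step from compound 2 to compound 3 is a step that the limit leaves unreadable from compound 2 to compound 3.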

Compound 3, half-maximal effective concentration: > 43400 nM
Compound 3 was reported as a limit; the forecaster's own chance of this, stated with the estimate: 80%; the middle value does not contradict the limit.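

Compound 3 gives only a limit in this assay, so the steps to it from compound 1 and compound 2 cannot be read: the limit of > 43400 nM in this assay, at which 3 of the 3 values shown sit.

The compounds shown leave open whether any group on this nitrogen gives a readable value in this assay.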